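The compounds below may be only part of what the source reports. "The series", "measured", "known", "first", "only" and "open" are said of these compounds alone.

Compound 1, `N#Cc1ccc(Nc2nccc(Oc3ccc(-c4ccc(C#N)cc4)c(F)c3F)n2)cc1`. In a functional assay on MT4 cells (Homo sapiens) for cytotoxicity, read by MTT assay, with a stated time of 5 days (a lower number here means that less compound is tolerated, a higher number that more compound is tolerated), compound 1 gives > 294000 nM, which is a limit of the assay rather than a number.
Compound 2, `N#Cc1ccc(Nc2nccc(Oc3ccc(-c4ccc(C#N)cc4)cc3F)n2)cc1`. In this assay compound 2 gives > 307000 nM, again a limit of the assay rather than a number.

Compound 2 therefore stands at a limit in this assay: no cytotoxicity was seen up to the highest concentration tested, so only a lower bound for its tolerated concentration is known, and the same holds for compound 1, as the limit of > 294000 nM in this assay, at which 1 of the 2 values shown sits, and the limit of > 307000 nM in this assay, at which 1 of the 2 values shown sits, show.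

Compound 3 is `N#Cc1ccc(Nc2nccc(Oc3c(F)cc(-c4ccc(C#N)cc4)cc3F)n2)cc1`. It differs from compound 2 by fluoro in place of hydrogen on an aromatic carbon. Among the measured compounds shown here, the one measured step that comes close is the change from compound 1 to compound 2 in this assay, a step that the two limits leave unreadable from compound 1 to compound 2, which removed a fluoro group from the same kind of position; because both ends of that step are limits, its size cannot be read. Neither limit gives reason to expect a change beyond the scatter when a fluoro group is put back.

Compound 3 is therefore expected to reach the limit of this assay as well, with the step from compound 2 to compound 3 estimated as an at least 1.0-fold lower number from compound 2 to compound 3 (0.01 log units; that floor lies within the scatter). The estimate for compound 3 in this assay is 300000 nM, within 150000 nM to 600000 nM.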

Compound 3, half-maximal cytotoxic concentration: > 294000 nM
Compound 3 ended at the assay's limit; the forecaster's own chance of this, stated with the estimate: 85%; the middle value is on the limit's open side.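

In this assay compound 3 gives > 294000 nM, again a limit of the assay rather than a number. Among the compounds shown here, compound 2 and compound 3 both stand at limits, so no step between them can be read. The compounds shown leave open where compound 1, compound 2 and compound 3 would each begin to harm these cells, and whether fluoro in place of hydrogen changes that.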